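Closing the amine tail of compound 3 into a ring

A few compounds are considered here, and "the series" means these few. Any claim that something is new, unique, unknown or untested is made for them only; others in the source may bear on it.

Of the compounds shown here, three sharing one core have been measured. Compound 1 `COc1cc(OC)c2c(=O)cc(-c3ccc(OCCBr)cc3)oc2c1` carries a bromoethoxy tail, compound 2 `COc1cc(OC)c2c(=O)cc(-c3ccc(OCCCN)cc3)oc2c1` a 3-aminopropoxy tail, and compound 3 `COc1cc(OC)c2c(=O)cc(-c3ccc(NCCN(C)C)cc3)oc2c1` a (2-(dimethylamino)ethyl)amino tail. In a functional assay (Homo sapiens) for antiproliferative activity, read by resazurin assay, with a stated time of 48 h, tested at 10 uM (a higher number here means a stronger effect of the compound at the concentration tested, a lower number a weaker effect), compound 1 gives "not active" (no number reported). In this assay compound 2 gives 39%, and compound 3 gives 60%. Among the measured compounds shown here, the only step between two numbered compounds is a number 21 percentage points higher from compound 2 to compound 3 (beyond the scatter). Compound 3 therefore holds the highest of the two numbers, with compound 2 as its nearest neighbour beyond the scatter.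

Compound 4 `COc1cc(OC)c2c(=O)cc(-c3ccc(NCCN4CCCC4)cc3)oc2c1` keeps the whole of compound 3 except for one change: pyrrolidin-1-yl in place of dimethylamino on a saturated chain carbon, two bonds along the chain from a nitrogen on an aromatic ring. For the measured compounds named here, no measured step concerns the amine at the end of this chain; the single step from compound 2 to compound 3 altered the linker and its attachment to the aromatic ring, not the terminal amine, so it gives only indirect guidance. With one basic nitrogen replaced by another of the same kind, a step in this assay no larger than the scatter is expected, in either direction, so the expected step is no change at the digits printed from compound 3 to compound 4 (within the scatter). Compound 4 is thus estimated at 60% in this assay, within 42% to 76%.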

Compound 4, a percentage reported as inhibition, at one concentration (the size of the read-out at that concentration, not a potency): 51%
Beside the measured number, compound 4's estimate is 9 percentage points above it; the range from low to high includes it.
By their numbers in this assay, from the lowest: compound 2; then compounds 4 and 3 (each within the scatter of the next).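

Replacing dimethylamino with pyrrolidin-1-yl at the end of the chain gives, in this assay, a number 9 percentage points lower from compound 3 to compound 4 (within the scatter), so at this position a five-membered non-aromatic ring of 5 heavy atoms can stand in for an open group of 3 heavy atoms without a change that can be told from the scatter. The ring-closed tail also stays clear of the 3-aminopropoxy tail, with a number 12 percentage points higher from compound 2 to compound 4 (beyond the scatter), so the result seen earlier for the (2-(dimethylamino)ethyl)amino tail is not limited to that one terminal amine. Nothing measured here explains either step, and no outside information on these changes is available.

From the compounds shown here alone, it remains open whether a six-membered ring such as piperidin-1-yl, or morpholin-4-yl with an oxygen in its ring, would give a similar read-out at the end of this chain, and whether a longer chain would hold the read-out at this level with either terminal amine. Going by these compounds, each number is also a read-out at a single concentration, so it gives the size of the effect at that concentration only, and how compound 3 and compound 4 would compare at other concentrations stays unknown.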